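The compounds below may be only part of what the source reports. "The series", "measured", "known", "first", "only" and "open" are said of these compounds alone.

In an assay on isolated protein for activation of cGMP-dependent protein kinase 1 (Homo sapiens), read by ADP-Glo, with stated times of 30 min and 2 h, in the presence of a further agent that is not named here (on this read-out higher numbers stand for an effect only at larger amounts of compound and lower numbers for an effect already at smaller amounts), compound 1 `OC[C@@H](O[C@H]1CCCN(Cc2ncc[nH]2)[C@H]1c1ccccc1)c1cc(Cl)cc(Cl)c1` gives 47000 nM and compound 2 `Nc1cc(C(=O)O)ccc1CN1CCC[C@H](O[C@H](CO)c2cc(Cl)cc(Cl)c2)[C@@H]1c1ccccc1` gives 290 nM. After the only measured step, a 160-fold lower number from compound 1 to compound 2 (2.21 log units; beyond the scatter), compound 2 stands with the lowest of the two numbers. Compound 3 `O=C(O)c1ccc(CN2CCC[C@H](O[C@H](CO)c3cc(Cl)cc(Cl)c3)[C@@H]2c2ccccc2)c(C2CC2)c1` differs from compound 2 by cyclopropyl in place of amino on an aromatic carbon. Among the compounds with values here, no measured step changes a single substituent on this aromatic carbon; the step from compound 1 to compound 2 exchanges the whole group and does not bear directly on this replacement. A step close to the scatter is therefore expected in this assay, a 1.2-fold higher number from compound 2 to compound 3 (0.08 log units; within the scatter). Compound 3 is estimated at 350 nM, with a range from 100 nM to 1200 nM.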

Compound 3, half-maximal effective concentration: 1800 nM
For compound 3 the middle estimate is 5.1-fold (0.71 log units) below the measured one, outside the stated range (above it).
By their numbers in this assay, from the lowest: compound 2; then compound 3; then compound 1.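

Working notes, this assay: the aromatic carbon that carries amino in compound 2 is sensitive to substitution, since cyclopropyl there costs potency (a 6.2-fold higher number from compound 2 to compound 3 (0.79 log units; beyond the scatter)). Compound 3 still keeps part of the gain over the imidazolyl compound (a 26-fold lower number from compound 1 to compound 3 (1.42 log units; beyond the scatter)), though less than compound 2 does (a 160-fold lower number from compound 1 to compound 2 (2.21 log units; beyond the scatter)). No measured evidence bears on the origin of this loss.

Going by these compounds, whether the loss follows from removing amino or from introducing cyclopropyl stays open. A hydroxyl, methyl or methoxy group on the same carbon would help separate the two.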